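Benzyltriazole fragment: removing the nitrile from compound 3

This account rests on a few compounds, and the source may have more. Where it says the series, first, only, none or still open, it means among the compounds named here.

The series is followed in an assay on isolated protein for inhibition of Aromatase (Homo sapiens), read by fluorescence and colorimetric assay, with a stated time of 30 min; a lower number here means a stronger inhibitor, a higher number a weaker inhibitor. Among the compounds with values here, compound 1 `N#Cc1ccc(C(c2ccc(C#N)cc2)n2cc(COc3ccc(Cl)cc3)nn2)cc1` gives 16100 nM, and compound 2 `N#Cc1ccc(C(c2ccc(C#N)cc2)n2cc(COc3ccc([N+](=O)[O-])cc3)nn2)cc1` gives 7730 nM; the one single-point step in hand is a 2.1-fold lower number from compound 1 to compound 2 (0.32 log units; beyond the scatter). Compound 3 `N#Cc1ccc(Cn2nccn2)cc1`, the small benzyltriazole fragment without the second aryl arm, gives 12200 nM, which is the second highest of the three numbers; its gap to compound 1 and its gap to compound 2 are both within the scatter, so the three numbers are not separated from one another by any ordered trend.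

The next step is to compound 4 `c1ccc(Cn2nccn2)cc1`. The change from compound 3 is hydrogen in place of cyano on an aromatic carbon. Within the data shown here, no measured pair in the set bears on this change: the only step recorded, from compound 1 to compound 2, swaps a nitro for a chloro on a remote phenoxy ring and says nothing about the nitrile on the benzyl ring. Among the measured compounds shown here, with no supporting step, the expectation for this assay rests on the weak starting point of compound 3 alone and is given with wide bounds; a step toward a somewhat higher number is expected, a 1.8-fold higher number from compound 3 to compound 4 (0.26 log units; within the scatter), though a result within the scatter would not surprise. Compound 4 is therefore estimated at 22000 nM, with a range from 8000 nM to 60000 nM.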

Compound 4, half-maximal inhibitory concentration: 16300 nM
For compound 4 the middle estimate is 1.3-fold (0.13 log units) above the measured one; the measured number falls inside the stated range.
By their numbers in this assay, from the lowest: compounds 2, 3, 1 and 4 (each within the scatter of the next, the first and the last beyond it).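

Hydrogen in place of cyano on an aromatic carbon of the six-membered aromatic ring, para to a group of 6 heavy atoms, gives a 1.3-fold higher number from compound 3 to compound 4 (0.13 log units; within the scatter) in this assay, so on the benzyltriazole fragment the nitrile cannot be told apart from hydrogen at this position. Within the data shown here, this is the first reading at this position, since the earlier step of a 2.1-fold lower number from compound 1 to compound 2 (0.32 log units; beyond the scatter) concerns a nitro-for-chloro change at a different place in the molecule and says nothing about the nitrile. Nothing available gives a reason for the size of this step.

Still open, as far as these compounds go, is whether a different group at this same carbon, such as a methoxy group, an amine or a carboxylic acid, would give a number that separates from those of compound 3 and compound 4 by more than the scatter. Also open, from the compounds shown here alone, is whether hydrogen in place of cyano would give a step of similar size on the larger core of compound 1, which also carries the nitrile, as the fragment pair alone cannot show how this change behaves with the second aryl arm and the triazole side chain present.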